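The compounds below may be only part of what the source reports. "The series", "measured", "known", "first", "only" and "open" are said of these compounds alone.

For the measured compounds named here, in a functional assay (aorta) with Rattus norvegicus as the target (on this read-out higher numbers stand for an effect only at larger amounts of compound and lower numbers for an effect already at smaller amounts), compound 3 `CNC1=NS(=O)(=O)c2cc(Cl)ccc2N1` gives 142 uM, the only actual number so far. Compound 1 `CNC1=NS(=O)(=O)c2cc(F)ccc2N1` reaches only a limit, > 300 uM. Compound 2 `O=S1(=O)NC(NC2CC2)=Nc2ccc(F)cc21` also reaches only a limit, > 300 uM. The next compound, compound 4 `O=S1(=O)N=C(NC2CC2)Nc2ccc(Cl)cc21`, has cyclopropyl in place of methyl on an amine nitrogen relative to compound 3: cyclopropyl in place of methyl on an amine nitrogen.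

Going by the values given here, the one measured step, an at least 2.1-fold lower number from compound 1 to compound 3 (0.32 log units; beyond the scatter), is chloro in place of fluoro on an aromatic carbon, a different change from this one. It does show that the chloro compound gives a number where its fluoro counterpart does not. The methyl and cyclopropyl fluoro pair, compound 1 and compound 2, sits at the same limit, so the size of the amine change is not measured. Without such a measurement, no step beyond the scatter is expected, and the estimate is a 1.1-fold lower number from compound 3 to compound 4 (0.04 log units; within the scatter). Compound 4 is estimated at 130 uM, with an expected range from 50 uM to 300 uM.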

Compound 4, concentration for half-maximal effect: 190 uM
Beside the measured number, compound 4's estimate is 1.5-fold (0.16 log units) below it; the measured number falls inside the stated range.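

With chloro on the aromatic carbon, the series gets its first readable size for cyclopropyl in place of methyl on an amine nitrogen in this assay: a 1.3-fold higher number from compound 3 to compound 4 (0.13 log units; within the scatter). In this chloro pair, methylamino and cyclopropylamino cannot be told apart on this read-out, and the three-membered ring still leaves a real number rather than a limit. The same change in the fluoro pair, compound 1 and compound 2, cannot be read, because both compounds rest on a limit of the assay: the limit of > 300 uM in this assay, at which 2 of the 4 values shown sit.

As far as these compounds go, whether this holds for other groups on the amine nitrogen, such as a longer chain or benzyl, remains open. Also open, from the compounds shown here alone, is how other groups in place of chloro on the aromatic carbon, such as bromo or trifluoromethyl, would read alongside methylamino and cyclopropylamino.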